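A few compounds are considered here, and "the series" means these few. Any claim that something is new, unique, unknown or untested is made for them only; others in the source may bear on it.

For the measured compounds named here, in a physicochemical assay for lipophilicity (on this read-out lower numbers stand for lower lipophilicity and higher numbers for higher lipophilicity), compound 2 (`CCCCCCCCS(=O)(=O)c1ccc(O)c(C(=O)Nc2ccc(C(F)(F)F)cc2)c1`) reads 6.3 and is the higher of the two numbers so far. Compound 1 (`CCCCCCS(=O)(=O)c1ccc(O)c(C(=O)Nc2ccc(Br)cc2)c1`) reads 5.2 in the same measurement, a gap beyond the usual scatter. The next entry is compound 3 (`CCCCCCS(=O)(=O)c1ccc(O)c(C(=O)Nc2ccc(C(F)(F)F)cc2)c1`), still unmeasured in this assay. Its structure departs from compound 2 by hydrogen in place of ethyl on a saturated chain carbon, six bonds along the chain from a sulfonyl sulfur in one place, that is hydrogen in place of ethyl on a saturated chain carbon, six bonds along the chain from a sulfonyl sulfur. The same difference, cut one bond further out, reads butyl to ethyl. Going by the values given here, the series holds no measured pair differing in one place, so the size of this change has no direct precedent here. A fall in this assay beyond the scatter is expected, and the estimated move is a number 1.00 log units lower from compound 2 to compound 3 (beyond the scatter) on this basis. The expectation leans on compound 1 at 5.2 as the closest measured reference, and it places the new number near that one. For compound 3 the estimated value is 5.3 (expected range 4.9 to 5.7) and the measurement is still to come.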

Compound 3, partition coefficient: 5.22
Compound 3: middle estimate off by 0.08 log units, on the high side, within the range that was stated.
By their numbers in this assay, from the lowest: compounds 1 and 3 (each within the scatter of the next); then compound 2.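

In this assay, the chain position now has its first measured step: hydrogen in place of ethyl on a saturated chain carbon, six bonds along the chain from a sulfonyl sulfur, gives a number 1.08 log units lower from compound 2 to compound 3 (beyond the scatter), a large step with trifluoromethyl held constant on the aromatic carbon. The aromatic position also has its first measured step, since trifluoromethyl in place of bromo on an aromatic carbon, with the chain held constant, gives a number 0.02 log units higher from compound 1 to compound 3 (within the scatter), so of these two single changes only the chain change moves the read-out in this assay beyond the scatter. Nothing at hand bears on why either step has the size it has.

One step at the chain position leaves open whether the read-out in this assay follows chain length evenly, and a longer chain or an intermediate one would be needed to give the shape of that trend. On these data alone, it also remains open whether the match between bromo and trifluoromethyl extends to other groups on that aromatic carbon, such as a nitrile, an amine or a carboxylic acid, or holds on the chain of compound 2.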